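The compounds below may be only part of what the source reports. "The series", "measured", "known", "first", "only" and "open" are said of these compounds alone.

Measured so far:
compound 1 `CCS(=O)(=O)Nc1cc(-c2ccc3ncnc(Nc4ccc(F)cc4F)c3c2)cnc1OC` — 4010 nM
compound 2 `CCS(=O)(=O)Nc1cc(-c2ccc3ncnc(Nc4ccc(OC)c(Cl)c4)c3c2)cnc1OC` — 5620 nM

Both numbers come from a functional assay on HCT-116 cells (Homo sapiens) for cytotoxicity, read by sulforhodamine B assay, with a stated time of 72 h; a lower number here means a stronger inhibitor, a higher number a weaker inhibitor. In this assay, for the measured compounds named here, compound 1 gives 4010 nM and compound 2 gives 5620 nM; the one step between them, a 1.4-fold higher number from compound 1 to compound 2 (0.15 log units; within the scatter), changes only the aryl group on the ring nitrogen and leaves the value within the scatter. Going by the values given here, compound 2 therefore stands together with compound 1, the only other measured compound, with no separation beyond the scatter between the two.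

Compound 3 `CCS(=O)(=O)Nc1cc(-c2ccc3ncnc(Nc4cccc(C(=O)OC)c4)c3c2)cnc1OC` is the next member and differs from compound 2 only at that same aryl group: 3-(methoxycarbonyl)phenyl in place of 3-chloro-4-methoxyphenyl on a nitrogen on an aromatic ring. Among the compounds with values here, the sole measured step that bears on this position is the one from compound 1 to compound 2, and it was within the scatter. Within the data shown here, nothing among the measured compounds shows that swapping the aryl on this nitrogen moves the number beyond the scatter, so the expected step in this assay is small, with no clear direction: a 1.1-fold lower number from compound 2 to compound 3 (0.05 log units; within the scatter) is the estimate. On that basis compound 3 is expected to give about 5000 nM in this assay, with a range from 2000 nM to 14000 nM.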

Compound 3, half-maximal inhibitory concentration: 400 nM
Compound 3: the middle estimate sits 13-fold (1.10 log units) above what was measured; the whole stated range lies above it.
By their numbers in this assay, from the lowest: compound 3; then compounds 1 and 2 (each within the scatter of the next).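

For the compounds shown here, the aryl group on this nitrogen is not a silent position in this assay: 3-(methoxycarbonyl)phenyl in place of 3-chloro-4-methoxyphenyl gives a 14-fold lower number from compound 2 to compound 3 (1.15 log units; beyond the scatter) and in place of 2,4-difluorophenyl gives a 10-fold lower number from compound 1 to compound 3 (1.00 log units; beyond the scatter), whereas the only earlier step at this place stayed within the scatter. Both new steps run the same way and lie beyond the scatter, so compound 3 stands apart as the strongest of the three, while compounds 1 and 2 remain together despite their different halogen-bearing aryl groups. The data available here give no reason for this separation.

From the compounds shown here alone, with a single ester-bearing compound, it remains open whether the number depends on the methoxycarbonyl group itself or would hold with a carboxylic acid, a primary amide or an ethyl ester in its place. Also open, going by these compounds, is whether 4-(methoxycarbonyl)phenyl or 2-(methoxycarbonyl)phenyl would keep the number of compound 3, or whether the same group only gives this result on the 3-substituted phenyl ring.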